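A Bromophenyl Swap in a Level Series

This account rests on a few compounds, and the source may have more. Where it says the series, first, only, none or still open, it means among the compounds named here.

In a functional assay on PC-3 cells (Homo sapiens) for cytotoxicity, read by MTT assay, with a stated time of 72 h (a higher number here means a weaker inhibitor, a lower number a stronger inhibitor), compound 1 `O=C(/C=C/c1ccc([N+](=O)[O-])cc1)Nc1cc2c(Nc3ccc(F)c(Cl)c3)ncnc2cc1O[C@H]1CCOC1` gives 22800 nM, compound 2 `O=C(/C=C/c1cccc(Cl)c1Cl)Nc1cc2c(Nc3ccc(F)c(Cl)c3)ncnc2cc1O[C@H]1CCOC1` gives 27500 nM, and compound 3 `COc1cc(/C=C/C(=O)Nc2cc3c(Nc4ccc(F)c(Cl)c4)ncnc3cc2O[C@H]2CCOC2)cc(OC)c1` gives 25600 nM. Compound 3 thus stands level with the other two, with gaps no larger than those between repeated measurements. Compound 4 `O=C(/C=C/c1ccc(Br)cc1)Nc1cc2c(Nc3ccc(F)c(Cl)c3)ncnc2cc1O[C@H]1CCOC1` carries one change from compound 3: 4-bromophenyl in place of 3,5-dimethoxyphenyl on a double-bonded chain carbon bound to a double-bonded chain carbon. Three measured steps swap a group at this same place: a 1.2-fold higher number from compound 1 to compound 2 (0.08 log units; within the scatter), a 1.1-fold higher number from compound 1 to compound 3 (0.05 log units; within the scatter) and a 1.1-fold lower number from compound 2 to compound 3 (0.03 log units; within the scatter). None of them leaves the scatter, so no step beyond the scatter is expected in this assay, though bromine itself has not yet been tested here. The expected size is a 1.0-fold lower number from compound 3 to compound 4 (0.01 log units; within the scatter). Compound 4 is estimated at 25000 nM, with an expected range of 14000 nM to 45000 nM.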

Compound 4, half-maximal inhibitory concentration: 28200 nM
Estimate against measurement, compound 4: 1.1-fold (0.05 log units) below; the range from low to high includes it.
By their numbers in this assay, from the lowest: compounds 1, 3, 2 and 4 (each within the scatter of the next).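

In this assay bromine, new at this place, stays level with all three earlier groups (a 1.1-fold higher number from compound 3 to compound 4 (0.04 log units; within the scatter)), (a 1.0-fold higher number from compound 2 to compound 4 (0.01 log units; within the scatter)) and (a 1.2-fold higher number from compound 1 to compound 4 (0.09 log units; within the scatter)). The series now holds four substituted phenyl groups that cannot be told apart here, even though 4-bromophenyl has fewer heavy atoms than 3,5-dimethoxyphenyl. Nothing available explains this level result.

As far as these compounds go, whether an amine or a carboxylic acid on the phenyl ring would shift the number stays open. So does the effect of replacing the phenyl ring with a longer chain.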